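Working notes on a methylsulfonyl-for-cyano step

The source may report more compounds than this note shows. Statements on the series, on what has been measured and on what is new or still open speak of the compounds shown alone.

Measured so far:
compound 1, `CC#C[C@@H](CC(=O)O)c1ccc(OC[C@H]2COc3ccc(C)cc3O2)cc1`, 78%
compound 2, `CC#C[C@@H](CC(=O)O)c1ccc(OC[C@H]2COc3ccc(C#N)cc3O2)cc1`, 60%

Within the data shown here, in a functional assay on HEK293 cells for agonist activity at Free fatty acid receptor 1 (Homo sapiens), read by fluorescence and calcium flux, with a stated time of 10 min (a higher number here means a larger maximal response, a lower number a smaller maximal response), compound 1 gives 78% and compound 2 gives 60%, so compound 2 stands lowest of the two numbers, with compound 1 the nearest and the only comparison. Among the measured compounds shown here, the one measured step is a number 18 percentage points lower from compound 1 to compound 2 (beyond the scatter), a modest loss beyond the scatter.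

The next compound is compound 3, `CC#C[C@@H](CC(=O)O)c1ccc(OC[C@H]2COc3ccc(S(C)(=O)=O)cc3O2)cc1`. Compared with compound 2 the change is methylsulfonyl in place of cyano on an aromatic carbon.

For the measured compounds named here, no measured step involves methylsulfonyl, so the move from cyano to methylsulfonyl has no direct precedent here. Going by the values given here, the only step that bears on it at all is a number 18 percentage points lower from compound 1 to compound 2 (beyond the scatter), which shows that a change at this aromatic carbon can shift the maximal response by a modest amount, in that case downward. That step does not tell the direction for compound 3. The expectation is therefore a step near zero or small, within or just beyond the scatter, in either direction, with the range set wide.

Compound 3 is estimated to give 58% in this assay, with a range from 40% to 76%, which means an expected step of a number 2 percentage points lower from compound 2 to compound 3 (within the scatter).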

Compound 3, largest response reached (Emax), in percent of the reference or control that the assay uses: 55%
Compound 3: middle estimate off by 3 percentage points, on the high side; measured number inside the range.
By their numbers in this assay, from the lowest: compounds 3 and 2 (each within the scatter of the next); then compound 1.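

In this assay, methylsulfonyl in place of cyano on this aromatic carbon gives a number 5 percentage points lower from compound 2 to compound 3 (within the scatter), so a group of 4 heavy atoms and 2 hydrogen-bond acceptors cannot be told apart here from one of 2 heavy atoms and 1 hydrogen-bond acceptor. Set against methyl, the same group gives a number 23 percentage points lower from compound 1 to compound 3 (beyond the scatter), and together with a number 18 percentage points lower from compound 1 to compound 2 (beyond the scatter) this makes two different replacements of methyl at this carbon that each bring the maximal response down by a modest amount beyond the scatter, where the earlier compounds offered only one such replacement. Nothing measured on these compounds accounts for the shared drop from methyl or for the lack of separation between cyano and methylsulfonyl.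

Going by these compounds, with only methyl, cyano and methylsulfonyl at this carbon, it stays open whether methyl is itself favourable for the maximal response or whether these two replacements merely happen to fall together. An ethyl group, a methoxy group, a chlorine atom or an amine at the same carbon would show whether the maximal response follows methyl or stays with the lower pair.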